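This account rests on a few compounds, and the source may have more. Where it says the series, first, only, none or still open, it means among the compounds named here.

Of the compounds shown here, three built on one shared core have been measured so far. Compound 1 `COc1cccc(-c2nc(SC)nc3sc(C(=O)NCc4ccccc4)c(N)c23)c1` gives 3% in a functional assay on HEK293 cells for agonist activity at Thyrotropin receptor (Homo sapiens), read by cAMP accumulation; on this read-out lower numbers stand for smaller maximal responses and higher numbers for larger maximal responses. Compound 2 `COc1cccc(-c2nc(SC)nc3sc(C(=O)NCC#N)c(N)c23)c1` gives 3.6% in this assay, and compound 3 `COc1cccc(-c2nc(SC)nc3sc(C(=O)NNC(C)(C)C)c(N)c23)c1` gives 6.4%. All three numbers sit within the scatter of one another: the step of a number 0.6 percentage points higher from compound 1 to compound 2 (within the scatter), the step of a number 3.4 percentage points higher from compound 1 to compound 3 (within the scatter) and the step of a number 2.8 percentage points higher from compound 2 to compound 3 (within the scatter) are each too small to count as a real change, so compound 3 stands level with compound 1 and compound 2 rather than apart from them.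

Compound 4 `COc1cccc(-c2nc(SC)nc3sc(C(=O)N(C)C)c(N)c23)c1` has not yet been measured. It differs from compound 3 in one place: dimethylamino in place of ((tert-butyl)amino)amino on a carbonyl carbon. The two steps that already touch this part of the molecule, from compound 1 to compound 3 and from compound 2 to compound 3, both alter the group on the amide-type nitrogen and both stay within the scatter. Among the measured compounds shown here, the change to compound 4 also alters only that group, so no step beyond the scatter is expected, neither upward nor downward. Compound 4 is therefore expected to give about 4.5% in this assay, between 1% and 11%, which means an expected step of a number 1.9 percentage points lower from compound 3 to compound 4 (within the scatter).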

Compound 4, largest response reached (reported as efficacy), in percent of the reference or control that the assay uses: 4%
The estimate for compound 4 lay 0.5 percentage points above the measured number; the range from low to high includes it.
By their numbers in this assay, from the lowest: compounds 1, 2, 4 and 3 (each within the scatter of the next).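

Compound 4 is the only one of the four whose amide nitrogen carries no hydrogen, and in this assay dimethylamino in place of ((tert-butyl)amino)amino, which goes from 6 heavy atoms and 2 hydrogen-bond donors to 3 and 0, gives a number 2.4 percentage points lower from compound 3 to compound 4 (within the scatter) and no real change. The comparisons with the other two amides read the same way, with a number 0.4 percentage points higher from compound 2 to compound 4 (within the scatter) and a number 1 percentage points higher from compound 1 to compound 4 (within the scatter) as the steps, so losing the amide hydrogen leaves compound 4 level with all three. No supporting data bear on why the response stays the same across these groups.

Still open, on these data alone, is whether a longer chain ending in an amine or a carboxylic acid on the amide nitrogen would move the response beyond the scatter. Also open, as far as these compounds go, is whether a change elsewhere on the shared core, such as a hydroxy group in place of the methoxy group, would do so.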